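This account rests on a few compounds, and the source may have more. Where it says the series, first, only, none or still open, it means among the compounds named here.

Working notes on the series. Compound 1 `CCCCCc1ccc2[nH]c(-c3ccc(OC)cc3)c(C=C(C#N)C#N)c2c1` and compound 2 `CCCCCCc1ccc2[nH]c(-c3ccc(OC)cc3)c(C=C(C#N)C#N)c2c1` share a core; the difference between that core and the core of compound 3 `CCCCc1ccc2[nH]c(-c3ccc(C)cc3)c(C=C(C#N)C#N)c2c1` is not broken down here. In a functional assay on MDA-MB-231 cells (Homo sapiens) for antiproliferative activity, with a stated time of 4 days (on this read-out lower numbers stand for stronger inhibition and higher numbers for weaker inhibition), compound 1 gives 42 nM, compound 2 gives 46 nM and compound 3 gives 65 nM. The change from compound 1 to compound 2 is methyl in place of hydrogen on a saturated chain carbon, five bonds along the chain from an aromatic carbon, and it made a 1.1-fold higher number from compound 1 to compound 2 (0.04 log units; within the scatter). Compound 4 `CCCCc1ccc2[nH]c(-c3ccc(CC)cc3)c(C=C(C#N)C#N)c2c1` is not yet measured in this assay. It stands to compound 3 as methyl in place of hydrogen on a saturated chain carbon bound to an aromatic carbon. For the measured compounds named here, this is the same kind of change as the one from compound 1 to compound 2, but not the same: there the methyl enters on a saturated chain carbon five bonds along the chain from an aromatic carbon, here on a saturated chain carbon bound to an aromatic carbon. Going by the values given here, only one measured step of this kind exists, and it lay within the scatter. Expected for the new pair is no change at the digits printed from compound 3 to compound 4 (within the scatter), resting on the earlier step of a 1.1-fold higher number from compound 1 to compound 2 (0.04 log units; within the scatter). Compound 4 is expected to give about 65 nM in this assay, estimated to fall between 30 nM and 140 nM.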

Compound 4, half-maximal inhibitory concentration: 76 nM
For compound 4 the middle estimate is 1.2-fold (0.07 log units) below the measured one; low and high end bracket the measured number.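

In this assay, methyl in place of hydrogen on a saturated chain carbon bound to an aromatic carbon gives a 1.2-fold higher number from compound 3 to compound 4 (0.07 log units; within the scatter), so this step cannot be told apart from repeat measurements. Set beside the earlier step, the same kind of change reads alike on both cores: the same change on two cores in this assay, a 1.1-fold higher number (0.04 log units; within the scatter) from compound 1 to compound 2 and a 1.2-fold higher number (0.07 log units; within the scatter) from compound 3 to compound 4, 1.1-fold (0.03 log units) apart, within the scatter of two such steps This shows only that the added methyl left the number within the scatter in both pairs; it does not show that the change is neutral in general, since the methyl enters at a different place in each pair and neither step is large enough to test whether a real effect carries over from one core to the other.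

On these data alone, whether a longer chain in place of the 4-ethylphenyl group's ethyl, or an amine or a carboxylic acid at that place, would move the number beyond the scatter stays open. Also open, as far as these compounds go, is whether these two steps would hold in any other cell line.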